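This account rests on a few compounds, and the source may have more. Where it says the series, first, only, none or still open, it means among the compounds named here.

Compound 3 `CCCc1nnc2sc(-c3c[nH]nc3-c3ccc(F)cc3)nn12` gives 12% in a functional assay on the whole organism (strain Wistar) for inhibition, with Rattus norvegicus as the target, read by paw edema, with stated times of 30 min and 2.5 h, at a dose of 20 mg/kg by the intraperitoneal route; a lower number here means less inhibition, a higher number more inhibition at the dose given (going by the name of the read-out); that is the lowest of the three numbers available, with compound 1 `CCc1nnc2sc(-c3c[nH]nc3-c3ccc(OC)cc3)nn12` standing nearest at 17.6%, a gap within the scatter, and compound 2 `CCCc1nnc2sc(-c3c[nH]nc3-c3ccccc3)nn12` standing furthest at 56.9%. Among the measured compounds shown here, the only single-place step seen so far is a number 44.9 percentage points lower from compound 2 to compound 3 (beyond the scatter). Compound 4 `CCCc1nnc2sc(-c3c[nH]nc3-c3ccc(OC)cc3)nn12` has not yet been measured; it differs from compound 3 at one place, (methoxy in place of fluoro on an aromatic carbon). For the measured compounds named here, no measured pair shows methoxy in place of fluoro on its own, so that step bears on compound 4 only indirectly. Compound 1 carries the same methoxy group but a shorter chain on the shared core, and its value sits close to that of compound 3, which suggests that the change from fluoro to methoxy does not by itself move the read-out far. The step from compound 3 to compound 4 is therefore expected to be small, a number 8 percentage points higher from compound 3 to compound 4 (within the scatter), if anything a modest rise. Compound 4 is estimated at 20% in this assay, within a range of 8% to 40%.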

Compound 4, a percentage reported as inhibition, in the whole organism at one dose (the size of the read-out at that dose, not a potency): 13.5%
For compound 4 the middle estimate is 6.5 percentage points above the measured one; low and high end bracket the measured number.
By their numbers in this assay, from the lowest: compounds 3, 4 and 1 (each within the scatter of the next); then compound 2.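

In this assay the change from 4-fluorophenyl to 4-methoxyphenyl gives a number 1.5 percentage points higher from compound 3 to compound 4 (within the scatter) and so, on this aromatic carbon, the two groups cannot be told apart. Methoxy in place of hydrogen at the same place gives a number 43.4 percentage points lower from compound 2 to compound 4 (beyond the scatter) and fluoro gives a number 44.9 percentage points lower from compound 2 to compound 3 (beyond the scatter), so the large fall appears with two different groups and is not peculiar to fluoro. With methoxy held fixed, methyl in place of hydrogen on the chain gives a number 4.1 percentage points lower from compound 1 to compound 4 (within the scatter) and thus shows no readable effect of chain length.

Going by these compounds, whether an amine, a hydroxyl or a carboxylic acid at this place would stay with compound 3 and compound 4 or come closer to compound 2 remains open, as does any effect of the chain when hydrogen sits on that carbon. Nothing at hand accounts for the fall seen with either group.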